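Methyl in place of fluoro: what to expect of compound 3

The compounds below may be only part of what the source reports. "The series", "measured", "known", "first", "only" and "open" are said of these compounds alone.

Within the data shown here, in a functional assay on a cell-free system (plasma, Oryctolagus cuniculus) for inhibition, with stated times of 5 min, 1 min and 6 min (on this read-out higher numbers stand for weaker inhibition and lower numbers for stronger inhibition), compound 1 `CCOC(=O)c1c(C)nc(-c2cccc(C#N)c2)n1OCCCO` gives 11400 nM and compound 2 `CCOC(=O)c1c(C)nc(-c2cccc(C#N)c2)n1OCc1ccc(F)cc1` gives 5880 nM as the only other number so far. These two stand within the scatter of each other, so compound 2 holds no clear place apart from compound 1. Compound 3 `CCOC(=O)c1c(C)nc(-c2cccc(C#N)c2)n1OCc1ccc(C)cc1` is still unmeasured and departs from compound 2 at one site, with methyl in place of fluoro on an aromatic carbon as the counted difference: methyl in place of fluoro on an aromatic carbon, para to a large group, which turns 4-fluorobenzyl into 4-methylbenzyl. Among the measured compounds shown here, the one measured step that bears on this does so only indirectly, namely a 1.9-fold lower number from compound 1 to compound 2 (0.29 log units; within the scatter) for 4-fluorophenyl in place of 2-hydroxyethyl on the chain. Even that wider exchange stayed within the scatter, and no measured pair varies the group on this ring. No step beyond the scatter is therefore expected in this assay in either direction. The expected step is a 1.0-fold higher number from compound 2 to compound 3 (0.01 log units; within the scatter) on this estimate. Compound 3 is estimated at 6000 nM with an expected range from 2800 nM to 12500 nM in this read-out.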

Compound 3, half-maximal inhibitory concentration: 6310 nM
Beside the measured number, compound 3's estimate is 1.1-fold (0.02 log units) below it, within the range that was stated.
By their numbers in this assay, from the lowest: compounds 2, 3 and 1 (each within the scatter of the next).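

In this assay, among these compounds, the ring carrying the substituent is varied directly for the first time: methyl in place of fluoro, para to a large group, gives a 1.1-fold higher number from compound 2 to compound 3 (0.03 log units; within the scatter) and so, at this place, separates 4-methylbenzyl from 4-fluorobenzyl by no measurable margin. The wider exchange, 4-methylphenyl in place of 2-hydroxyethyl on the chain, gives a 1.8-fold lower number from compound 1 to compound 3 (0.26 log units; within the scatter) and thus reads the same way as the earlier exchange with 4-fluorophenyl, which gave a 1.9-fold lower number from compound 1 to compound 2 (0.29 log units; within the scatter) in the same assay, so neither para group takes its compound clear of compound 1. No independent measurement is available that could explain these numbers.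

The compounds shown leave open whether a group of another kind para to a large group, such as an amine, a carboxylic acid or a methoxy group, would produce a step beyond the scatter. Also open, from the compounds shown here alone, is whether a longer chain carrying the aromatic ring, or an exchange of the nitrile or the ethyl ester on the shared core, would do so in this read-out.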